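Assigning the ring stereocentre in a weak piperidin-3-yl analogue

This account rests on a few compounds, and the source may have more. Where it says the series, first, only, none or still open, it means among the compounds named here.

Of the compounds shown here, three have been measured in an assay on membranes from brain for binding affinity to Lysophosphatidylserine lipase ABHD12 (Mus musculus), read by fluorescence, with a stated time of 20 min; on this read-out higher numbers stand for weaker inhibition and lower numbers for stronger inhibition. Compound 1 `FC(F)(F)Oc1ccc(Oc2ccnc(N3CCC(NC(=S)Nc4cccnc4)CC3)c2Cl)c(Cl)c1` gives 11 nM. Compound 2 `FC(F)(F)Oc1ccc(Oc2ccnc(N3CCCC(NC(=S)Nc4cccnc4)C3)c2Cl)c(Cl)c1` gives 90000 nM. Compound 3 `FC(F)(F)c1cnc(N2CCC(NC(=S)Nc3cccnc3)CC2)c(Cl)c1` gives 1100 nM. Compound 2 stands at the highest of the three numbers: its nearest neighbour is compound 3, beyond the scatter, and its furthest is compound 1, also beyond the scatter. Within the data shown here, no pair among the measured compounds differs in a single place, so no step can be read directly from them.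

Compound 4 `FC(F)(F)Oc1ccc(Oc2ccnc(N3CCC[C@@H](NC(=S)Nc4cccnc4)C3)c2Cl)c(Cl)c1` has not yet been measured. It differs from compound 2 only in stereochemistry: the two compounds have the same atoms and bonds; at least one stereo element is drawn with a configuration in one of them and without one in the other: 1 of 1 stereo elements differ; a stereocentre at a saturated ring carbon is drawn without a configuration in compound 2 and R in compound 4. Compound 2 thus stands for material of undefined configuration at that ring carbon, and compound 4 for one of its two possible forms.

Because compound 2 gives 90000 nM, the most that the defined form can gain is what an unresolved mixture hides, and the step of a 1.5-fold lower number from compound 2 to compound 4 (0.18 log units; within the scatter) is expected to fall within the scatter, if anything toward the lower side. Compound 4 is estimated at 60000 nM in this assay, with a range from 20000 nM to 200000 nM, the upper end allowing for an assay limit at this weak level.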

Compound 4, half-maximal inhibitory concentration: 100000 nM
The estimate for compound 4 lay 1.7-fold (0.22 log units) below the measured number; the range from low to high includes it.
By their numbers in this assay, from the lowest: compound 1; then compound 3; then compounds 2 and 4 (each within the scatter of the next).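

In this assay the R form at the saturated ring carbon and the material of undefined configuration read alike, with a 1.1-fold higher number from compound 2 to compound 4 (0.05 log units; within the scatter). Compound 4 gives 100000 nM, so the R form shows no strength that the undefined material of compound 2 had been concealing, and at this ring carbon defining the configuration as R does not separate the two compounds on this read-out. This reading rests on a single structural difference between the pair: the fact that one of compounds 2 and 4 is drawn with a defined configuration and the other without, at the place where they differ.

As far as these compounds go, the S form at that ring carbon remains open, and with it the question of whether compound 2 holds any share of a form that reads differently from compound 4. Also open, from the compounds shown here alone, is how this ring carbon would read in this assay with a urea carbonyl in place of the thiocarbonyl, or with a primary amine in place of the whole thiourea chain.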